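Free amine or acetamide on the branched side chain

The source may report more compounds than this note shows. Statements on the series, on what has been measured and on what is new or still open speak of the compounds shown alone.

Compound 3 `CC[C@H](C)[C@@H](CN(C(=O)[C@@H]1C[C@H]1c1ccccc1)c1ccc(-c2ccccc2)cc1)NC(C)=O` holds the lowest number among the values in hand: in a functional assay for agonist activity at G protein-coupled receptor 88 (Homo sapiens), read by HTRF and cAMP accumulation (a lower number here means that less compound is needed, a higher number that more compound is needed for the effect), compound 3 gives 5.8 nM. Compound 1 `CC(C)C[C@H](N)CN(C(=O)[C@@H]1C[C@H]1c1ccccc1)c1ccc(-c2ccccc2)cc1` gives 880 nM in this assay. Compound 2 `CC(C)CCCN(C(=O)[C@@H]1C[C@H]1c1ccccc1)c1ccc(-c2ccccc2)cc1` reaches only a limit in this assay, > 100 nM (the limit of > 100 nM in this assay, at which 1 of the 3 values shown sits). The measured steps are a 150-fold lower number from compound 1 to compound 3 (2.18 log units; beyond the scatter), an at least 17-fold lower number from compound 2 to compound 3 (1.23 log units; beyond the scatter) and a step that the limit leaves unreadable from compound 1 to compound 2. Compound 4 `CC(C)[C@H](N)CN(C(=O)[C@@H]1C[C@H]1c1ccccc1)c1ccc(-c2ccccc2)cc1` carries 1-amino-2-methylpropyl in place of 1-acetamido-2-methylbutyl on a saturated chain carbon bound to an amide-type nitrogen. This change removes the acetyl group that compound 3 carries and returns to a free amine of the kind found in compound 1, on a shorter branched chain. The large step of a 150-fold lower number from compound 1 to compound 3 (2.18 log units; beyond the scatter) bundles the acetylation with the chain change, so undoing most of it is expected to give back much of that gain. For compound 4 the expected step is a 100-fold higher number from compound 3 to compound 4 (2.01 log units; beyond the scatter) in this assay. The estimate for compound 4 is 600 nM, with a range from 150 nM to 3000 nM.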

Compound 4, half-maximal effective concentration: 1.1 nM
For compound 4 the middle estimate is 550-fold (2.74 log units) above the measured one; the measured number lies below the stated range.
By their numbers in this assay, from the lowest: compound 4; then compound 3; then compound 1.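

A free amine does not by itself mean a high number at this position: 1-amino-2-methylpropyl in place of 1-acetamido-2-methylbutyl gives a 5.3-fold lower number from compound 3 to compound 4 (0.72 log units; beyond the scatter) in this assay, so the acetyl group is not needed for a low value. Among the free amines, the side chain matters greatly, as isopropyl in place of isobutyl on a saturated chain carbon bound to an amine nitrogen and a saturated chain carbon gives an 800-fold lower number from compound 1 to compound 4 (2.90 log units; beyond the scatter). 1-Amino-2-methylpropyl in place of isopentyl gives an at least 90-fold lower number from compound 2 to compound 4 (1.95 log units; beyond the scatter), a step that rests on a limit: the limit of > 100 nM in this assay, at which 1 of the 4 values shown sits.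

The step from compound 3 to compound 4 changes both the acetyl group and the chain length, and only 1-acetamido-2-methylpropyl would separate the two. From the compounds shown here alone, how a tert-butyl or a longer branched chain on the amine-bearing carbon would read also stays open.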